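This account rests on a few compounds, and the source may have more. Where it says the series, first, only, none or still open, it means among the compounds named here.

Measured in a functional assay on MCF7 cells (Homo sapiens) for inhibition, read by sulforhodamine B assay, with a stated time of 48 h; on this read-out lower numbers stand for stronger inhibition of growth and higher numbers for weaker inhibition of growth:
- compound 1 `N#CCC1=NN=C(c2ccc([N+](=O)[O-])cc2)CO1`: 1 nM
- compound 2 `N#CCC1=C(C#N)CC(c2ccc(Br)cc2)=C(CC(=O)c2ccc([N+](=O)[O-])cc2)O1`: 90 nM

Compound 1 holds the lower of the two numbers, and the gap up to compound 2 lies well beyond the usual scatter of repeated measurements. Compound 3 `N#CCC1=NN=C(c2ccc(Br)cc2)CO1` keeps the core of compound 1 and changes one group: bromo in place of nitro on an aromatic carbon. In short, it has bromo in place of nitro on an aromatic carbon. Among the compounds with values here, no pair of measured compounds shows this change alone, and compound 2 differs too widely from compound 1 to serve as a guide. A number as low as that of compound 1 at 1 nM leaves more room to rise than to fall, so a moderate rise is expected in this assay, meaning somewhat weaker inhibition of growth. The estimated step is an 8.0-fold higher number from compound 1 to compound 3 (0.90 log units; beyond the scatter). Compound 3 is expected at about 8 nM, with an estimated range of 1 nM to 60 nM.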

Compound 3, concentration for 50% growth inhibition: 1500 nM
Compound 3: the middle estimate sits 190-fold (2.27 log units) below what was measured, and the stated range ends below it.
By their numbers in this assay, from the lowest: compound 1; then compound 2; then compound 3.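

Placing bromo in place of nitro on an aromatic carbon gives a 1500-fold higher number from compound 1 to compound 3 (3.18 log units; beyond the scatter) in this assay, so this one position, para to a group of 9 heavy atoms, has a very large influence on the read-out. Compound 1 and compound 2 differ in too many places to reveal this, whereas compound 1 and compound 3 differ only in this group. Nothing in the data explains why this single change matters so much.

Going by these compounds, it remains open whether nitro is uniquely favorable here or bromo is specifically unfavorable, which an amine, a methoxy group or a carboxylic acid on the same carbon could help to separate. It is also unknown whether the same change would have a similar effect on a different core.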